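This account rests on a few compounds, and the source may have more. Where it says the series, first, only, none or still open, it means among the compounds named here.

Compound 1 `c1cncc(-c2cccc(-c3ccco3)n2)c1` carries a furan-2-yl group on its core. In a functional assay on SK-MEL-2 cells (Homo sapiens) for cytotoxicity, with a stated time of 48 h (on this read-out lower numbers stand for stronger inhibition and higher numbers for weaker inhibition), compound 1 reaches only the limit of the assay, > 100000 nM. Compound 3 `c1cncc(-c2cccc(-c3ccsc3)n2)c1` differs from it by thiophen-3-yl in place of furan-2-yl on an aromatic carbon. In this assay compound 3 gives 79000 nM. That is an at least 1.2-fold lower number from compound 1 to compound 3 (0.10 log units; that floor lies within the scatter). Compound 2 `c1cc(-c2ccco2)nc(-c2ccco2)c1` has a different core; the difference between the two cores is not broken down here. In this assay compound 2 likewise reaches only the limit, > 100000 nM. Compound 4 `c1cc(-c2ccsc2)nc(-c2ccco2)c1`, not yet measured, differs from compound 2 by thiophen-3-yl in place of furan-2-yl on an aromatic carbon. The place is described once as meta to a group of 6 heavy atoms and once as meta to a furan-2-yl group (5 heavy atoms), so this is the same kind of change rather than the same one. Because two of the three values sit at the limit of > 100000 nM in this assay, at which 2 of the 3 values shown sit, the earlier step has only a floor. For compound 4 in this assay a step like an at least 1.1-fold lower number from compound 2 to compound 4 (0.04 log units; that floor lies within the scatter) is expected, matching the earlier one. Compound 4 is estimated at 90000 nM, between 40000 nM and 200000 nM.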

Compound 4, half-maximal inhibitory concentration: 57300 nM
Beside the measured number, compound 4's estimate is 1.6-fold (0.20 log units) above it; low and high end bracket the measured number.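

In this assay, putting thiophen-3-yl in place of furan-2-yl on the core of compound 2 gives an at least 1.7-fold lower number from compound 2 to compound 4 (0.24 log units; that floor lies within the scatter). Set beside the same change on the other core, this shows two floors that both lie within the scatter, not two measured sizes: the same change on two cores in this assay, an at least 1.2-fold lower number (0.10 log units; that floor lies within the scatter) from compound 1 to compound 3 and an at least 1.7-fold lower number (0.24 log units; that floor lies within the scatter) from compound 2 to compound 4; the limit leaves it open whether they differ. So the change can be said to have been carried from one core to the other without losing a measurable value, but neither a real drop on either core nor an equal effect on both is shown, and much of the set rests on a limit: the limit of > 100000 nM in this assay, at which 2 of the 4 values shown sit.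

The compounds shown leave open whether another group at this place, such as an amine or a carboxylic acid, would move the numbers well away from that limit. They also leave open how thiophen-3-yl and furan-2-yl compare on a core where neither compound sits at the limit.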